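Halogen Swap on the Saturated Ring Carbon

The compounds below may be only part of what the source reports. "The series", "measured", "known", "first", "only" and "open" are said of these compounds alone.

Compound 2 `COc1cc(C2=NN(C(C)=O)C(c3ccc(Cl)c(Cl)c3)O2)cc(OC)c1OC` gives 26.1% in a functional assay on PC-3 cells (Homo sapiens) for antiproliferative activity, read by MTT assay, tested at 5 uM (a higher number here means a stronger effect of the compound at the concentration tested, a lower number a weaker effect), the lowest of the three values shown. Compound 1 `COc1cc(C2=NN(C(C)=O)C(c3cccc(OC)c3OC)O2)cc(OC)c1OC` gives 58.2%, and compound 3 `COc1cc(C(=O)N/N=C/c2ccc(F)cc2)cc(OC)c1OC` gives 82.8%. Compound 4 `COc1cc(C2=NN(C(C)=O)C(c3ccc(F)c(F)c3)O2)cc(OC)c1OC` differs from compound 2 by 3,4-difluorophenyl in place of 3,4-dichlorophenyl on a saturated ring carbon. Among the measured compounds shown here, the only measured step at a saturated ring carbon, a number 32.1 percentage points lower from compound 1 to compound 2 (beyond the scatter), shows that 3,4-dichlorophenyl in place of 2,3-dimethoxyphenyl lowered the read-out sharply; no measured step compares 3,4-dichlorophenyl with 3,4-difluorophenyl. As compound 2 and compound 4 both carry a dihalogenated phenyl on a saturated ring carbon, only a small change is expected, possibly a modest rise. Compound 4 is therefore expected to give 32%, within 15% to 50%. The expected step is a number 5.9 percentage points higher from compound 2 to compound 4 (within the scatter).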

Compound 4, a percentage reported as inhibition, at one concentration (the size of the read-out at that concentration, not a potency): 46.9%
Estimate against measurement, compound 4: 14.9 percentage points below, within the range that was stated.
By their numbers in this assay, from the lowest: compound 2; then compound 4; then compound 1; then compound 3.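

In this assay, two dihalogenated phenyl groups on this saturated ring carbon do not read alike: 3,4-difluorophenyl in place of 3,4-dichlorophenyl gives a number 20.8 percentage points higher from compound 2 to compound 4 (beyond the scatter), so the halogen itself counts at this position. Against 2,3-dimethoxyphenyl, 3,4-difluorophenyl still gives a number 11.3 percentage points lower from compound 1 to compound 4 (beyond the scatter), recovering only part of the loss seen with 3,4-dichlorophenyl. Nothing available explains the difference between the two halogens. Still open, going by these compounds, is how a plain phenyl or a phenyl bearing an amine would read at this carbon.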